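This account rests on a few compounds, and the source may have more. Where it says the series, first, only, none or still open, it means among the compounds named here.

In a functional assay on MDA-MB-435 cells (Homo sapiens) for cytotoxicity, read by MTT assay, with a stated time of 72 h (on this read-out lower numbers stand for stronger inhibition and higher numbers for weaker inhibition), three compounds sharing one core have been measured. Compound 1 `O=C(NCc1ccc(F)cc1)c1nc(Br)c2cccnc2c1NCc1ccc(F)cc1` gives only a limit, > 20000 nM. Compound 2 `O=C(NCc1ccc(F)cc1)c1nc(Br)c2cccnc2c1NCCO` also gives only a limit, > 20000 nM. For the measured compounds named here, compound 3 `O=C(NCc1ccc(F)cc1)c1nc(Br)c2cccnc2c1N1CCNCC1`, at 8000 nM, is the only one with an actual number. Compound 4 `Cc1ccc(S(=O)(=O)Oc2c(C(=O)NCc3ccc(F)cc3)nc(Br)c3cccnc23)cc1` carries ((4-methylphenyl)sulfonyl)oxy in place of piperazin-1-yl on an aromatic carbon. Two measured steps involve this same place, an at least 2.5-fold lower number from compound 1 to compound 3 (0.39 log units; beyond the scatter) and an at least 2.5-fold lower number from compound 2 to compound 3 (0.39 log units; beyond the scatter). Going by these compounds, both favour piperazin-1-yl, so losing it should move the number back up, although the entering group itself is untested. The expected change is a 2.5-fold higher number from compound 3 to compound 4 (0.40 log units; beyond the scatter), towards weaker inhibition. For compound 4 the estimated value is 20000 nM, within an expected range from 6000 nM to 60000 nM.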

Compound 4, half-maximal inhibitory concentration: > 20000 nM
Compound 4 was reported as a limit; the forecaster's own chance of this, stated with the estimate: 55%; the middle value sits exactly at the limit.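

In this assay, ((4-methylphenyl)sulfonyl)oxy in place of piperazin-1-yl gives an at least 2.5-fold higher number from compound 3 to compound 4 (0.39 log units; beyond the scatter). Until now only groups joined through nitrogen had been compared at this aromatic carbon; this group is joined through oxygen, and piperazin-1-yl remains the only group shown here that gives an actual number. The steps among compounds 1, 2 and 4 cannot be read, because all three stop at one limit: the limit of > 20000 nM in this assay, at which 3 of the 4 values shown sit.

Going by these compounds, whether the piperazin-1-yl result depends on its second ring nitrogen remains open. Morpholin-4-yl, which has oxygen in that place, or an open-chain 2-aminoethylamino group could separate the ring from that nitrogen.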